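The compounds below may be only part of what the source reports. "The series", "measured", "known", "first", "only" and "open" are said of these compounds alone.

Measured so far:
compound 1, `CCNc1nc(NCc2ccccc2)nc(-c2ccccc2CO)n1`, 4.63
compound 2, `Nc1nc(NCc2cccc(Cl)c2)nc(-c2ccccc2CO)n1`, 4.97
compound 3, `Nc1nc(NCc2cccc(C(F)(F)F)c2)nc(-c2ccccc2CO)n1`, 5.11

In a functional assay on cells for positive allosteric modulation of G-protein coupled receptor 68 (Homo sapiens), read by a luciferase reporter and cAMP accumulation, with a stated time of 30 min, at pH 6.8 and pH 8.3, in the presence of a further agent that is not named here (on this read-out lower numbers stand for lower potency and higher numbers for higher potency (the scale is a negative logarithm)), compound 2 gives 4.97, the second highest of the three numbers. The nearest neighbour is compound 3, at 5.11, and the step of a number 0.14 log units higher from compound 2 to compound 3 (within the scatter) is within the scatter, so the two are not separated. Compound 1 stands furthest away, at 4.63, beyond the scatter; it differs from compound 2 in two places, so its gap cannot be assigned to one change.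

Compound 4, `Nc1nc(NCCCc2ccccc2)nc(-c2ccccc2CO)n1`, has not yet been measured. Relative to compound 2 the change is phenethyl in place of 3-chlorophenyl on a saturated chain carbon bound to a nitrogen on an aromatic ring. Among the compounds with values here, no measured step in this set bears directly on it: the one counted step, trifluoromethyl for chloro, swaps one ring substituent for another and leaves the chain untouched, and it is itself within the scatter. Within the data shown here, compound 1 shows only that an unsubstituted ring on that chain carbon, together with a further change elsewhere, goes with a lower number. Loss of the chloro and lengthening of the chain is therefore expected to cost something, a modest drop, a number 0.27 log units lower from compound 2 to compound 4 (within the scatter), but with wide uncertainty. The estimate for compound 4 in this assay is 4.7, within a range of 4.3 to 5.1.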

Compound 4, negative logarithm of the antagonist equilibrium constant: 5.22
Compound 4: the middle estimate sits 0.52 log units below what was measured, and the stated range ends below it.
By their numbers in this assay, from the lowest: compound 1; then compounds 2, 3 and 4 (each within the scatter of the next).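

Phenethyl in place of 3-chlorophenyl on a saturated chain carbon bound to a nitrogen on an aromatic ring gives, in this assay, a number 0.25 log units higher from compound 2 to compound 4 (within the scatter) and so does not separate the two compounds. Within the data shown here, this is the first reading of a change to the chain itself, since the earlier step between compounds that differ in one place only swapped one ring substituent for another. It shows that, at this position, compound 4 keeps a number level with compound 2 while carrying a ring with no chloro and no trifluoromethyl, so neither group is required for a value in this range. Nothing in hand accounts for this result.

The compounds shown do not separate the effect of the added chain length from that of the lost chloro, as the two changes arrive together in compound 4. Also open, from the compounds shown here alone, is how this position would respond to a longer chain, or to an amine or a carboxylic acid in place of the ring.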